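Methyl in Place of Fluorine on a Cyclopropyl Amide

This account rests on a few compounds, and the source may have more. Where it says the series, first, only, none or still open, it means among the compounds named here.

Of the compounds shown here, three sharing one core have been measured in an assay on SH-EP1 cells for agonist activity at Neuronal acetylcholine receptor; alpha4/beta2 (Homo sapiens), read by FLIPR and calcium flux; a higher number here means that more compound is needed for the effect, a lower number that less compound is needed. Compound 1 `CCCC(=O)N1CC2CC(C1)N2` carries a propyl group on its carbonyl carbon and gives 580 nM. Compound 2 `O=C([C@H]1C[C@H]1F)N1CC2CC(C1)N2` has a 2-fluorocyclopropyl ring in place of that chain and gives 210 nM, a step of a 2.8-fold lower number from compound 1 to compound 2 (0.44 log units; beyond the scatter). Compound 3 `O=C([C@@H]1C[C@H]1F)N1CC2CC(C1)N2` carries the same ring with one stereocentre drawn the other way and gives 120 nM; the step from compound 1 is a 4.8-fold lower number from compound 1 to compound 3 (0.68 log units; beyond the scatter), while the step of a 1.8-fold lower number from compound 2 to compound 3 (0.24 log units; within the scatter). Compound 3 thus has the lowest number of the three, although its gap to compound 2 is within the scatter, so those two cannot be ranked against each other.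

The next compound, compound 4 `C[C@H]1C[C@H]1C(=O)N1CC2CC(C1)N2`, differs from compound 3 in one place: 2-methylcyclopropyl in place of 2-fluorocyclopropyl on a carbonyl carbon. Among the measured compounds shown here, no measured step swaps a fluorine for a methyl; the steps from compound 1 to compound 2 and to compound 3 show only that a substituted cyclopropyl ring in place of propyl lowers the number modestly. With the ring kept and only its substituent exchanged, the expected step of a 1.3-fold higher number from compound 3 to compound 4 (0.10 log units; within the scatter) is none beyond the scatter. Compound 4 is therefore estimated at 150 nM, with a range from 60 nM to 400 nM.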

Compound 4, half-maximal effective concentration: 2200 nM
Compound 4: middle estimate off by 15-fold (1.17 log units), on the low side, outside the stated range (above it).
By their numbers in this assay, from the lowest: compounds 3 and 2 (each within the scatter of the next); then compound 1; then compound 4.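

In this assay, a methyl group and a fluorine on the same cyclopropyl ring, at this place on the carbonyl carbon, are clearly not interchangeable: exchanging fluorine for methyl gives an 18-fold higher number from compound 3 to compound 4 (1.26 log units; beyond the scatter) and, measured against the other fluorinated compound, a 10-fold higher number from compound 2 to compound 4 (1.02 log units; beyond the scatter). The earlier compounds shown here suggested that a substituted cyclopropyl ring lowers the number relative to a propyl chain, but this no longer holds for every substituent, since the methyl-bearing ring gives a 3.8-fold higher number from compound 1 to compound 4 (0.58 log units; beyond the scatter), so the substituent on the ring matters as well as the ring itself. No measurement shown here bears on why methyl and fluorine differ so sharply at this position.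

The compounds shown leave open where a plain cyclopropyl ring, or one bearing a chlorine or a hydroxyl group, would fall relative to the fluorine and methyl versions. Also open, as far as these compounds go, is whether the other stereo arrangement of the 2-methylcyclopropyl group would give a number like that of compound 4 or one closer to those of the fluorinated compounds.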